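Hydroxy at the chain end: compound 3 to compound 4

The source may hold more compounds than are shown below. What is called first, only, known or untested is meant among the compounds shown, and "the series" means these compounds.

In a functional assay on MCF-10A cells (Homo sapiens) for antiproliferative activity, with a stated time of 48 h (a higher number here means that more compound is needed for the effect, a lower number that less compound is needed), compound 1 (`Cc1cc(NCc2ccc(F)cc2)c2ccccc2n1`) gives 20100 nM. Compound 2 (`CCCCCCCCOc1ccc2nc(C)cc(NCc3ccc(F)cc3)c2c1`) gives 2200 nM, and compound 3 (`CCCCCCCCCCOc1ccc2nc(C)cc(NCc3ccc(F)cc3)c2c1`) gives 2000 nM. Compound 3 therefore sits level with compound 2 within the scatter, and both values lie far under that of compound 1.

Compound 4 (`Cc1cc(NCc2ccc(F)cc2)c2cc(OCCCCCCO)ccc2n1`) has hydroxy in place of butyl on a saturated chain carbon, six bonds along the chain from an oxygen on an aromatic ring.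

For the measured compounds named here, two measured steps bear on this change. Octyloxy in place of hydrogen on an aromatic carbon gave a 9.1-fold lower number from compound 1 to compound 2 (0.96 log units; beyond the scatter). Ethyl at the chain end then gave a 1.1-fold lower number from compound 2 to compound 3 (0.04 log units; within the scatter). Going by the values given here, no measured step places a hydroxy on the chain, so this expectation rests on indirect evidence. Part of the drop seen in a 9.1-fold lower number from compound 1 to compound 2 (0.96 log units; beyond the scatter) is expected to survive in compound 4, but not all of it.

The expected move is a 3.0-fold higher number from compound 3 to compound 4 (0.48 log units; beyond the scatter), towards a higher number. For compound 4 the estimate is 6000 nM, with an expected range of 2000 nM to 20000 nM.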

Compound 4, half-maximal effective concentration: 11300 nM
For compound 4 the middle estimate is 1.9-fold (0.27 log units) below the measured one; the measured number falls inside the stated range.
By their numbers in this assay, from the lowest: compounds 3 and 2 (each within the scatter of the next); then compounds 4 and 1 (each within the scatter of the next).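

In this assay, the chain end at this position matters: hydroxy in place of butyl on a saturated chain carbon, six bonds along the chain from an oxygen on an aromatic ring, gives a 5.7-fold higher number from compound 3 to compound 4 (0.75 log units; beyond the scatter) and, against the octyloxy chain, a 5.1-fold higher number from compound 2 to compound 4 (0.71 log units; beyond the scatter) on the same carbon. The earlier step showed only that lengthening the chain changed nothing beyond the scatter, whereas this change does move the number. Set against the bare core, the hydroxy-ended chain gives a 1.8-fold lower number from compound 1 to compound 4 (0.25 log units; within the scatter) and so does not retain the gain seen with octyloxy; nothing available explains this loss.

The compounds shown leave open how much of the rise belongs to the hydroxy and how much to the shorter chain, since a plain hexyloxy chain is not among them. Also open, from the compounds shown here alone, is how a terminal amine or carboxylic acid, or a hydroxy on a decyloxy chain, would compare.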